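The source may report more compounds than this note shows. Statements on the series, on what has been measured and on what is new or still open speak of the compounds shown alone.

Working notes on the hydrazide series built on the shared dichloropyridine core of compound 1 `O=C(CCc1ccc(Cl)cc1)NNc1c(Cl)cncc1Cl`. In a functional assay on HEK293 cells for antagonist activity at P2X purinoceptor 7 (Homo sapiens), read by fluorescence, with a stated time of 2 h (a higher number here means a weaker inhibitor, a lower number a stronger inhibitor), compound 1 gives 1100 nM, the lowest of the three numbers recorded so far, though every gap to the others falls within the scatter. Going by the values given here, compound 2 `COc1ccc(CCC(=O)NNc2c(Cl)cncc2Cl)cc1` gives 1500 nM; the single change, methoxy in place of chloro on an aromatic carbon, produces a 1.4-fold higher number from compound 1 to compound 2 (0.13 log units; within the scatter). Compound 3 `O=C(CCCCc1ccccc1)NNc1c(Cl)cncc1Cl` gives 1200 nM; it differs from compound 1 in more than one place, so only the two values themselves can be set side by side, and they lie close together.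

Compound 4 `O=C(CCC1CCCC1)NNc1c(Cl)cncc1Cl` is the next member to be tested in this assay. The change from compound 1 is cyclopentyl in place of 4-chlorophenyl on a saturated chain carbon, two bonds along the chain from a carbonyl carbon. Among the compounds with values here, no measured step covers the exchange of an aromatic ring for a saturated one at this position; the only step that touches this end of the molecule, from compound 1 to compound 2, alters a substituent on the aromatic ring and stays within the scatter, and compound 3 with its longer chain to the phenyl gives a number close to compound 1. Within the data shown here, with no precedent for removing the aromatic ring, the expected step is a loosening of potency, a 2.3-fold higher number from compound 1 to compound 4 (0.36 log units; beyond the scatter), with wide uncertainty. Compound 4 is estimated at 2500 nM, within 900 nM to 7000 nM.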

Compound 4, half-maximal inhibitory concentration: 380 nM
Compound 4: middle estimate off by 6.6-fold (0.82 log units), on the high side; the whole stated range lies above it.
By their numbers in this assay, from the lowest: compound 4; then compounds 1, 3 and 2 (each within the scatter of the next).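

In this assay, the 4-chlorophenyl group of compound 1 proves replaceable at this place on the chain: cyclopentyl in its place gives a 2.9-fold lower number from compound 1 to compound 4 (0.46 log units; beyond the scatter). Going by these compounds alone, the earlier step at this end of the molecule, a 1.4-fold higher number from compound 1 to compound 2 (0.13 log units; within the scatter), changed only a substituent on the aromatic ring and stayed within the scatter, so this is the first step to lie beyond it, and it shows that the number can fall with one five-membered non-aromatic ring of carbon only in place of the aromatic ring. Nothing available bears on why the number falls.

The compounds shown leave open whether this step belongs to the saturated ring as such or to its size, and cyclohexyl or an open-chain group such as tert-butyl on the same chain carbon would help to separate the two. Also open, from the compounds shown here alone, is whether a longer chain to the cyclopentyl ring would keep the number seen for compound 4, 380 nM, or whether the shorter chain is needed to hold it.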